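Chain extension by one carbon on two related cores

This account rests on a few compounds, and the source may have more. Where it says the series, first, only, none or still open, it means among the compounds named here.

Compound 1 `CCn1nc(-c2ccnc(Nc3cccc(S(N)(=O)=O)c3)n2)c2ccccc21` and compound 2 `CCCn1nc(-c2ccnc(Nc3cccc(S(N)(=O)=O)c3)n2)c2ccccc21` share a core and differ by methyl in place of hydrogen on a saturated chain carbon, two bonds along the chain from an aromatic nitrogen. In a functional assay on MCF7 cells (Homo sapiens) for antiproliferative activity, read by MTT assay, with a stated time of 72 h (on this read-out lower numbers stand for stronger inhibition of growth and higher numbers for weaker inhibition of growth), compound 1 gives 7260 nM and compound 2 gives 4260 nM, a step of a 1.7-fold lower number from compound 1 to compound 2 (0.23 log units; within the scatter). Compound 3 `Cc1nn(-c2ccnc(Nc3ccc(S(N)(=O)=O)cc3)n2)c2ncccc12` has a different core; the difference between the two cores is not broken down here. In this assay compound 3 gives 8640 nM, within the scatter of compound 1 and beyond the scatter of compound 2.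

Compound 4 `CCc1nn(-c2ccnc(Nc3ccc(S(N)(=O)=O)cc3)n2)c2ncccc12` differs from compound 3 by methyl in place of hydrogen on a saturated chain carbon bound to an aromatic carbon. This is the same kind of change as that from compound 1 to compound 2, but around the place it differs: there the carbon is two bonds along the chain from an aromatic nitrogen, here it is bound to an aromatic carbon. Within the data shown here, only one example of this change is measured, and it stayed within the scatter. An estimated step of a 1.4-fold lower number from compound 3 to compound 4 (0.16 log units; within the scatter) in this assay is expected, resting on the step of a 1.7-fold lower number from compound 1 to compound 2 (0.23 log units; within the scatter). Compound 4 is thus expected at about 6000 nM, with a range from 3000 nM to 12000 nM.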

Compound 4, concentration for 50% growth inhibition: 880 nM
For compound 4 the middle estimate is 6.8-fold (0.83 log units) above the measured one; the measured number lies below the stated range.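

In this assay the change of hydrogen to methyl on a saturated chain carbon bound to an aromatic carbon gives a 9.8-fold lower number from compound 3 to compound 4 (0.99 log units; beyond the scatter) and is the only step in this series shown beyond the scatter. The same kind of change therefore did not carry over in size from one core to the other, and a step read on one core is a poor guide to the step on the other: the same change on two cores in this assay, a 1.7-fold lower number (0.23 log units; within the scatter) from compound 1 to compound 2 and a 9.8-fold lower number (0.99 log units; beyond the scatter) from compound 3 to compound 4, 5.8-fold (0.76 log units) apart, beyond the scatter of two such steps. With a single pair on each core, this does not show whether the core or the place of the chain accounts for the gap, as the two pairs differ in both, and it gives no rule for the series beyond compounds 1 to 4.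

The compounds shown leave open whether a longer chain such as propyl, or a branched chain such as isopropyl, on the core of compound 3 would keep the number of compound 4. They also leave open how a polar group such as an amine or a hydroxyl at the end of that chain would read.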